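Ethyl for phenyl on the ring nitrogen of compound 1

This account rests on a few compounds, and the source may have more. Where it says the series, first, only, none or still open, it means among the compounds named here.

Compounds measured so far:
compound 1 `O=C1CS/C(=N/Nc2nncc3ccccc23)N1c1ccccc1` — 32 nM
compound 2 `NS(=O)(=O)c1ccc(Nc2nncc3ccccc23)cc1` — 23 nM
compound 3 `O=S(=O)(Nc1nccs1)c1ccc(Nc2nncc3ccccc23)cc1` — 56 nM

The three compounds were tested in a functional assay on COLO 205 cells (Homo sapiens) for antiproliferative activity, read by sulforhodamine B assay, with a stated time of 72 h; on this read-out lower numbers stand for stronger inhibition and higher numbers for weaker inhibition. Compound 1 gives the second highest of the three numbers. Compound 2 is nearest to it, within the scatter, and compound 3, the furthest, is also within the scatter of compound 1. For the measured compounds named here, the only step between measured neighbours is a 2.4-fold higher number from compound 2 to compound 3 (0.39 log units; beyond the scatter), which changes a sulfonamide nitrogen, a site absent from compound 1.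

Compound 4 `CCN1C(=O)CS/C1=N/Nc1nncc2ccccc12` differs from compound 1 by ethyl in place of phenyl on an amide-type nitrogen in a ring. Going by the values given here, no measured step touches this amide-type nitrogen in a ring, so the data give no direct precedent; the one measured step elsewhere was modest. An estimate for compound 4 in this assay therefore rests on compound 1 alone and is expected to lie near the measured number of compound 1, 32 nM, with a step of a 1.4-fold higher number from compound 1 to compound 4 (0.15 log units; within the scatter) not expected to go beyond the scatter. The expected value for compound 4 is 45 nM, within a range from 15 nM to 140 nM.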

Compound 4, half-maximal inhibitory concentration: 43 nM
For compound 4 the middle estimate is 1.0-fold (0.02 log units) above the measured one; measured number inside the range.
By their numbers in this assay, from the lowest: compounds 2, 1, 4 and 3 (each within the scatter of the next, the first and the last beyond it).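

In this assay, ethyl in place of phenyl on the amide-type nitrogen in a ring gives a 1.3-fold higher number from compound 1 to compound 4 (0.13 log units; within the scatter). For the compounds shown here, this is the first measured step at this position, and it shows that the six-membered aromatic ring of carbon only can give way to ethyl, which has no ring, without a change beyond the scatter, so a number of this size does not depend on phenyl here. No available evidence bears on why the two groups read alike.

Going by these compounds, whether a longer chain such as butyl, or a chain ending in an amine or a carboxylic acid, would also stay within the scatter of compound 1 remains open. On these data alone, it is also open how a cyclohexyl or pyridyl ring would read on this nitrogen.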